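This account rests on a few compounds, and the source may have more. Where it says the series, first, only, none or still open, it means among the compounds named here.

Working notes on the series.

Compound 2, `COc1cc2nc(N3CCC[C@H](NC4=CC(=O)c5ccccc5C4=O)C3)nc(N)c2cc1OC`, gives 0.525 nM in an assay on CHO cells for displacement of a labelled ligand from Alpha-1B adrenergic receptor (Homo sapiens), with a stated time of 30 min; a lower number here means a stronger inhibitor, a higher number a weaker inhibitor. Compound 2 stands with the lowest of the two numbers measured; compound 1, `COc1cc2nc(N3CCC[C@@H](N)C3)nc(N)c2cc1OC`, gives 178 nM in this assay, a gap far beyond the scatter. Going by the values given here, no stepwise pair of measured compounds is recorded, so nothing has yet been seen of how a change in configuration alone moves the numbers.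

Compound 3, `COc1cc2nc(N3CCC[C@@H](NC4=CC(=O)c5ccccc5C4=O)C3)nc(N)c2cc1OC`, is the next compound to be measured in this assay. Compared with compound 2 it shows (the two compounds have the same atoms and bonds and differ only in configuration as drawn: 1 of 1 stereo elements differ; a stereocentre at a saturated ring carbon is drawn S in compound 2 and R in compound 3).

Among the compounds with values here, with no measured pair to lean on, the expectation for compound 3 is a step upward in this assay relative to compound 2, of moderate size and beyond the scatter, in line with a 9.5-fold higher number from compound 2 to compound 3 (0.98 log units; beyond the scatter). Compound 3 is therefore estimated at 5 nM, with a range from 1 nM to 30 nM, the direction resting on compound 2 having given 0.525 nM.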

Compound 3, inhibition constant: 25.1 nM
For compound 3 the middle estimate is 5.0-fold (0.70 log units) below the measured one; the measured number falls inside the stated range.
By their numbers in this assay, from the lowest: compound 2; then compound 3; then compound 1.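

In this assay, inverting the saturated ring carbon from S to R gives a 48-fold higher number from compound 2 to compound 3 (1.68 log units; beyond the scatter), so the number at this position depends strongly on configuration as drawn. The step can be assigned to that stereocentre alone, and the basis is: the fact that compounds 2 and 3 differ only in the configuration as drawn Compound 1 and compound 2 differ in more than one place and gave no view of configuration on its own, whereas here the shared core and substituent stay fixed and the S form holds the lower number.

On these data alone, whether the same order of S and R holds with an acetyl amide or a benzyl group in place of the substituent that compound 2 and compound 3 share remains open. The numbers also leave unexplained how configuration produces a step of this size.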